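The source may report more compounds than this note shows. Statements on the series, on what has been measured and on what is new or still open speak of the compounds shown alone.

Among the compounds with values here, the three compounds measured so far share one core. Compound 1 `CCCCC(=O)OCc1ccc2oc(=O)c(C(=O)Oc3cccc(Br)c3)cc2c1` gives 63.3% in a functional assay on HT-1080 cells (Homo sapiens), read by transwell migration, with a stated time of 24 h, tested at 1 uM; a lower number here means a stronger effect, a higher number a weaker effect of the compound at the concentration tested. Within the data shown here, compound 2 `CC(C)C(=O)OCc1ccc2oc(=O)c(C(=O)Oc3cccc(Br)c3)cc2c1` gives 37.8% in this assay, and the change a number 25.5 percentage points lower from compound 1 to compound 2 (beyond the scatter) is the only step between two measured compounds that differ in a single place. Compound 3 `CC(=O)NCc1ccc2oc(=O)c(C(=O)Oc3ccccc3)cc2c1` gives 63.5% in this assay; this is the highest of the three numbers, though compound 1 lies within the scatter of it, while compound 2 sits well apart from both.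

Compound 4 `CC(=O)NCc1ccc2oc(=O)c(C(=O)Oc3cccc(Br)c3)cc2c1` has not yet been measured in this assay. It differs from compound 3 by bromo in place of hydrogen on an aromatic carbon, a bromo in place of hydrogen on an aromatic carbon, meta to a large group. Among the measured compounds shown here, no measured step touches this bromo: the only step recorded, from compound 1 to compound 2, concerns isopropyl in place of butyl on a carbonyl carbon, and compounds 1 and 2 both carry the bromo already. There is therefore nothing to anchor a shift in either direction, and the step of a number 3.5 percentage points lower from compound 3 to compound 4 (within the scatter) is expected to stay within the scatter. Compound 4 is estimated to give about 60% in this assay, with a range from 40% to 80%.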

Compound 4, a percentage reported as activity, at one concentration (the size of the read-out at that concentration, not a potency): 36.9%
For compound 4 the middle estimate is 23.1 percentage points above the measured one; the whole stated range lies above it.
By their numbers in this assay, from the lowest: compounds 4 and 2 (each within the scatter of the next); then compounds 1 and 3 (each within the scatter of the next).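

Bromo in place of hydrogen on the aromatic carbon, meta to a large group, is the first change at this position that can be read, and in this assay the step is a number 26.6 percentage points lower from compound 3 to compound 4 (beyond the scatter) with the acetamido side chain in place. With the bromo kept, the side chain does not act in one direction: acetamido in place of (isopropylcarbonyl)oxy gives a number 0.9 percentage points lower from compound 2 to compound 4 (within the scatter), while acetamido in place of (butylcarbonyl)oxy gives a number 26.4 percentage points lower from compound 1 to compound 4 (beyond the scatter), so the acetamido group matches the isopropyl ester and parts from the butyl ester. Nothing at hand explains why the bromo moves the number this far.

The compounds shown leave open whether the bromo step carries over to the ester side chains, since neither ester appears here on the unsubstituted phenyl ring. They also leave open whether a chloro, a methoxy or a trifluoromethyl group on the same aromatic carbon would do what the bromo does, and how a longer amide chain than acetamido would read.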